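Sulfonate Anilides: Shrinking the Amide Aryl Group

This account rests on a few compounds, and the source may have more. Where it says the series, first, only, none or still open, it means among the compounds named here.

Measured compounds:
- compound 1 `COc1ccc(S(=O)(=O)Oc2ccccc2NC(=O)c2ccc3ncccc3c2)cc1`: a functional assay on HCT-15 cells (Homo sapiens) for antiproliferative activity; on this read-out higher numbers stand for weaker inhibition and lower numbers for stronger inhibition > 10000 nM
- compound 2 `COc1ccc(S(=O)(=O)Oc2ccccc2NC(=O)c2ccnc3ccccc23)cc1`: this assay > 10000 nM

Compound 2 stands at a limit of this assay; the value given for compound 2 is a limit and not a number. The same holds for compound 1, whose value is likewise a limit. The step that the two limits leave unreadable from compound 1 to compound 2 therefore cannot be read in size or direction. The only evidence on the measured compounds is the limit of > 10000 nM in this assay, at which 2 of the 2 values shown sit, which places both shown values at the same limit.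

Compound 3 `COc1ccc(S(=O)(=O)Oc2ccccc2NC(=O)c2cccnc2)cc1` is the next compound to be measured. Its difference from compound 2 is pyridin-3-yl in place of quinolin-4-yl on a carbonyl carbon. No measured step bears on this change, since the one step shown is hidden by the two limits. Nothing in the two measured values points to a gain in potency, and a change within the usual scatter is the expectation.

Compound 3 is therefore expected to give about 10000 nM in this assay, within 3000 nM and 30000 nM, which is an expected step of a number no higher from compound 2 to compound 3 (the limit leaves the size open) from compound 2, most likely reported again as a limit.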

Compound 3, half-maximal inhibitory concentration: > 3000 nM
Compound 3 was reported as a limit; the forecaster's own chance of this, stated with the estimate: 80%; the middle value lies beyond the limit too.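

In this assay compound 3 gives > 3000 nM, which is a limit and not a number. All three values are limits, so the steps from compound 1 and compound 2 to compound 3 cannot be read in size or direction. The compounds shown leave open whether quinolin-6-yl, quinolin-4-yl and pyridin-3-yl differ at all in this assay.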